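The source may report more compounds than this note shows. Statements on the series, on what has been measured and on what is new or still open speak of the compounds shown alone.

In an ADME assay on the whole organism (Mus musculus, strain ICR), read by HPLC, with a stated time of 24 h, at a dose of 50 mg/kg by the oral route (a lower number here means that the compound disappears faster, a higher number that the compound lasts longer), compound 1 `CCc1nc2ccc(Br)cn2c1C(=O)NCCOc1ccc(N2CCC(C(F)(F)F)CC2)cc1` gives 1.88 h and compound 2 `CCc1nc2ccc(Cl)cn2c1C(=O)NCCOc1ccc(N2CCN(c3ccc(F)cc3)CC2)cc1` gives 3.56 h as mean residence time. These two numbers lie within the usual scatter of each other, so they cannot be told apart, and the two structures differ in more than one place. Compound 3 `CCc1nc2ccc(Br)cn2c1C(=O)NCCOc1ccc(N2CCCCC2)cc1` is compound 1 with a single edit: hydrogen in place of trifluoromethyl on a saturated ring carbon, which is hydrogen in place of trifluoromethyl on a saturated ring carbon, so that 4-(trifluoromethyl)piperidin-1-yl becomes piperidin-1-yl. Among the compounds with values here, no measured pair shows this edit alone, so the best anchor is compound 1 itself at 1.88 h in this assay and the direction remains uncertain. The step of a 1.2-fold lower number from compound 1 to compound 3 (0.07 log units; within the scatter) is expected to be a small drop that stays within the scatter. For compound 3 the expected value is 1.6 h with 0.8 h to 3.2 h as its estimated range.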

Compound 3, mean residence time: 2.82 h
For compound 3 the middle estimate is 1.8-fold (0.25 log units) below the measured one; the measured number falls inside the stated range.
By their numbers in this assay, from the lowest: compounds 1, 3 and 2 (each within the scatter of the next).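

Within the data shown here, this is the first pair of compounds that differ in one place only, so the trifluoromethyl group can now be judged on its own. In this assay, putting hydrogen in place of trifluoromethyl on the saturated ring carbon, three ring bonds from the ring nitrogen, gives a 1.5-fold higher number from compound 1 to compound 3 (0.18 log units; within the scatter). Taking the whole group away from this place therefore has no effect that can be told apart from the ordinary spread of repeated measurements, and nothing measured here offers an explanation for that result.

From the compounds shown here alone, whether a different group on this same ring carbon, such as a methyl, a hydroxyl or an amine, would move the number beyond the scatter stays open. Going by these compounds, this is also a single pair, so it remains unknown whether the same edit would read alike on another part of the series, such as a compound with chlorine on the shared core.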